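The source may hold more compounds than are shown below. What is called first, only, known or untested is meant among the compounds shown, and "the series" means these compounds.

Compound 1 `O=C1Nc2ccccc2/C1=N/NC(=S)NC1CCCCC1`: 4380 nM.
Compound 2 `CN(C)c1ccc(NC(=S)N/N=C2\C(=O)Nc3ccccc32)cc1`: 2320 nM.
Compound 3 `O=C1Nc2ccccc2/C1=N/NC(=S)Nc1ccc(C(=O)O)cc1`: > 50000 nM.

All three compounds were tested in a functional assay on KB-V1 cells (Homo sapiens) for cytotoxicity, read by MTT assay, with a stated time of 72 h; a lower number here means a stronger inhibitor, a higher number a weaker inhibitor. Compound 3 has no number, only a limit of the assay, and sits at the limit of > 50000 nM in this assay, at which 1 of the 3 values shown sits.

Compound 4 `CC(C)(C)c1ccc(NC(=S)N/N=C2\C(=O)Nc3ccccc32)cc1` keeps the shared core but carries tert-butyl in place of carboxy on an aromatic carbon, para to a large group: tert-butyl in place of carboxy on an aromatic carbon. Among the measured compounds shown here, the one measured step that bears on this change is an at least 21-fold higher number from compound 2 to compound 3 (1.33 log units; beyond the scatter), which brought in the carboxy. Neither compound 2 at 2320 nM nor compound 1 at 4380 nM has a carboxy, so a large step to a lower number is expected once it leaves. The expected step is an at least 17-fold lower number from compound 3 to compound 4 (1.25 log units; beyond the scatter). The estimate for compound 4 is 2800 nM, with an expected range from 900 nM to 9000 nM.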

Compound 4, half-maximal inhibitory concentration: 710 nM
Estimate against measurement, compound 4: 3.9-fold (0.60 log units) above; measured number outside the range, below it.
By their numbers in this assay, from the lowest: compound 4; then compounds 2 and 1 (each within the scatter of the next). At a limit, above all of these: compound 3.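

In this assay, the change from carboxy to tert-butyl gives an at least 70-fold lower number from compound 3 to compound 4 (1.84 log units; beyond the scatter), though compound 3 has only a limit of the assay and no number: the limit of > 50000 nM in this assay, at which 1 of the 4 values shown sits. Removing carboxy is not the whole story at this place, para to a large group, since the group that enters also counts: tert-butyl in place of dimethylamino gives a 3.3-fold lower number from compound 2 to compound 4 (0.51 log units; beyond the scatter). The compounds shown leave open whether a methyl group, a chlorine atom or a methoxy group at this place would match tert-butyl, and whether an ester or amide would restore the activity lost with carboxy.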